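Replacing the sulfonyl amino group of compound 2 with a nonyl chain

A few compounds are considered here, and "the series" means these few. Any claim that something is new, unique, unknown or untested is made for them only; others in the source may bear on it.

Compound 1, `COc1ccc(-c2cn(C/C=C3\OC(=O)C(OCc4ccccc4)=C3OCc3ccccc3)nn2)cc1`, gives in a functional assay on HepG2 cells (Homo sapiens) for antiproliferative activity, read by MTT assay, with a stated time of 72 h (on this read-out lower numbers stand for stronger inhibition and higher numbers for weaker inhibition), only a limit, > 100000 nM.
Compound 2, `O=C1O[C@H]([C@@H](O)Cn2cc(CNS(=O)(=O)c3ccc(F)cc3)nn2)C(OCc2ccccc2)=C1OCc1ccccc1`, gives in this assay 18300 nM.
Compound 3, `CCCCCc1ccc(-c2cn(C/C=C3\OC(=O)C(OCc4ccccc4)=C3OCc3ccccc3)nn2)cc1`, gives in this assay only a limit, > 100000 nM.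

Compound 2 is the only one of the three with a number in this assay; the other two sit at the limit of > 100000 nM in this assay, at which 2 of the 3 values shown sit. Between compound 1 and compound 3 the change is a step that the two limits leave unreadable from compound 1 to compound 3, so nothing can be read from that pair. Compound 4, `CCCCCCCCCCc1cn(C[C@H](O)[C@H]2OC(=O)C(OCc3ccccc3)=C2OCc2ccccc2)nn1`, is to be measured in this assay. It differs from compound 2 in one place: nonyl in place of ((4-fluorophenyl)sulfonyl)amino on a saturated chain carbon bound to an aromatic carbon. Within the data shown here, no measured step touches this kind of change, since compound 1 and compound 3 carry the shared core of compound 2 in another arrangement and both reach only a limit. The step from compound 2 to compound 4 is therefore an open guess, and a result anywhere from well inside the scatter to a limit is conceivable. Compound 4 is estimated at 15000 nM, with a range from 3000 nM to 80000 nM, which would mean an expected step of a 1.2-fold lower number from compound 2 to compound 4 (0.09 log units; within the scatter).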

Compound 4, half-maximal inhibitory concentration: 12200 nM
Estimate against measurement, compound 4: 1.2-fold (0.09 log units) above, within the range that was stated.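

In this assay, among these compounds, nonyl in place of ((4-fluorophenyl)sulfonyl)amino on a saturated chain carbon bound to an aromatic carbon gives a 1.5-fold lower number from compound 2 to compound 4 (0.18 log units; within the scatter), the first step that can be read. At this place, then, the group with the six-membered aromatic ring, the hydrogen-bond donor and the hydrogen-bond acceptors can give way to an all-carbon chain without a change beyond the scatter. The earlier compounds shown here could not show this, since the step between compound 1 and compound 3 cannot be read, both values being limits.

Going by these compounds, it remains open whether a shorter or longer chain, or a chain ending in an amine or a carboxylic acid, would move the value beyond the scatter. Nothing measured here gives a reason for this result.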